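This account rests on a few compounds, and the source may have more. Where it says the series, first, only, none or still open, it means among the compounds named here.

Compound 2 `C=CC(=O)Nc1cccc(NC(=O)CSc2nc(Nc3ccc(CC)cc3)c3ccccc3n2)c1` and compound 1 `C=CC(=O)Nc1cccc(NC(=O)CSc2nc(Nc3ccc(Cl)cc3)c3ccccc3n2)c1` share one core and differ only in the group carried on the aryl ring attached to the ring nitrogen. In a functional assay on MDA-MB-231 cells (Homo sapiens) for inhibition, read by MTT assay, with a stated time of 72 h (on this read-out higher numbers stand for weaker inhibition and lower numbers for stronger inhibition), compound 1 gives 10300 nM, and compound 2 gives 14400 nM. Among the measured compounds shown here, compound 2 therefore holds the higher of the two numbers measured so far, but the step of a 1.4-fold higher number from compound 1 to compound 2 (0.15 log units; within the scatter) is small, so the two compounds cannot be ranked against each other.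

Compound 3 `C=CC(=O)Nc1cccc(NC(=O)CSc2nc(Nc3cc(OC)c(OC)c(OC)c3)c3ccccc3n2)c1` keeps the same core and alters that same aryl ring: 3,4,5-trimethoxyphenyl in place of 4-ethylphenyl on a nitrogen on an aromatic ring. For the measured compounds named here, the only measured step that bears on this position is the one from compound 1 to compound 2, and it stayed within the scatter. Going by the values given here, that step, however, exchanged one small group for another, whereas the new change brings in three methoxy groups, so it is a larger alteration than anything measured here, and no step speaks to it directly. On that basis the expected step of a 1.2-fold lower number from compound 2 to compound 3 (0.08 log units; within the scatter) is none beyond the scatter. For compound 3 the estimated value in this assay is 12000 nM, within a range from 4500 nM to 32000 nM.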

Compound 3, half-maximal inhibitory concentration: > 50000 nM
Compound 3 ended at the assay's limit; the forecaster's own chance of this, stated with the estimate: 8%; at least 4.1-fold (0.61 log units) between middle value and limit.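

Until now this position had shown no step beyond the scatter, but a larger change to the aryl group on the nitrogen does: the measured steps are an at least 3.4-fold higher number from compound 2 to compound 3 (0.54 log units; beyond the scatter) and an at least 4.8-fold higher number from compound 1 to compound 3 (0.68 log units; beyond the scatter). The position is therefore not indifferent to what it carries, since 3,4,5-trimethoxyphenyl, with 12 heavy atoms and 3 hydrogen-bond acceptors, gives weaker inhibition in this assay than either the 4-ethylphenyl or the 4-chlorophenyl group, even though those two could not be told apart. Compound 3 stands at a limit of the assay rather than at a number, and how far its true value lies past that point remains unknown: the limit of > 50000 nM in this assay, at which 1 of the 3 values shown sits.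

The compounds shown cannot tell whether the loss of inhibition needs all three methoxy groups or whether a phenyl ring with a single methoxy group would already produce it. They also leave open how this position would respond to an amine or a carboxylic acid on the ring, or to a longer alkyl chain in place of the ethyl group.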